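A few compounds are considered here, and "the series" means these few. Any claim that something is new, unique, unknown or untested is made for them only; others in the source may bear on it.

Measured so far in a functional assay on SMMC-7721 cells (Homo sapiens) for cytotoxicity, read by MTT assay, with a stated time of 24 h; on this read-out higher numbers stand for weaker inhibition and lower numbers for stronger inhibition:
- Compound 1 `O=C1/C(=C/c2cccnc2)CNC/C1=C\c1ccccc1F`: > 20000 nM, a limit
- Compound 2 `Cc1ccc(S(=O)(=O)N2C/C(=C\c3cccnc3)C(=O)/C(=C/c3ccccc3F)C2)cc1`: 10300 nM
- Compound 3 `O=C1/C(=C/c2cccnc2)CN(S(=O)(=O)c2ccc([N+](=O)[O-])cc2)C/C1=C\c1ccccc1F`: > 20000 nM, a limit

Compound 3 has no numerical value. It sits at the limit of > 20000 nM in this assay, at which 2 of the 3 values shown sit. Within the data shown here, compound 2 is the only compound in the set with a measured number.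

Compound 4 `O=C1/C(=C/c2cccnc2)CN(S(=O)(=O)c2ccc(Cl)cc2)C/C1=C\c1ccccc1F` changes compound 3 in one place: chloro in place of nitro on an aromatic carbon. This puts chloro in place of nitro on an aromatic carbon, para to a large group, so 4-nitrophenyl becomes 4-chlorophenyl.

Among the measured compounds shown here, two measured steps bear on this change. The closer one, with nitro in place of methyl on an aromatic carbon, is an at least 1.9-fold higher number from compound 2 to compound 3 (0.28 log units; that floor lies within the scatter). The other, which adds (4-methylphenyl)sulfonyl on the ring nitrogen, is an at least 1.9-fold lower number from compound 1 to compound 2 (0.28 log units; that floor lies within the scatter). For the measured compounds named here, both are bounded on one side only, so their true sizes remain open, and no chloro compound has been measured.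

The nearest numerical anchor is compound 2 at 10300 nM, so a reading for compound 4 is expected near that value. The expected change is a modest move towards a lower number, possibly none beyond the scatter, and the estimated step is an at least 1.5-fold lower number from compound 3 to compound 4 (0.18 log units; that floor lies within the scatter). A result at the assay limit is also expected to remain quite possible. For compound 4 the estimate is 13000 nM, with an expected range of 6000 nM to 25000 nM.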

Compound 4, half-maximal inhibitory concentration: 16100 nM
For compound 4 the middle estimate is 1.2-fold (0.09 log units) below the measured one; measured number inside the range.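

In this assay, the 4-chlorophenyl compound gives the series a second measured number at this position, and the change from methyl to chloro reads as a 1.6-fold higher number from compound 2 to compound 4 (0.19 log units; within the scatter), so the two groups cannot be told apart in this read-out. The change from nitro to chloro reads as an at least 1.2-fold lower number from compound 3 to compound 4 (0.09 log units; that floor lies within the scatter), and adding the (4-chlorophenyl)sulfonyl group to the ring nitrogen reads as an at least 1.2-fold lower number from compound 1 to compound 4 (0.09 log units; that floor lies within the scatter); both are floors only, so neither step establishes a real gain, though a second sulfonyl compound now returns a number in this assay. The true sizes of these two steps stay unknown, since compound 1 and compound 3 carry limits and not numbers: the limit of > 20000 nM in this assay, at which 2 of the 4 values shown sit.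

Still open, on these data alone, is whether any group on this aromatic carbon moves the number beyond the scatter, for instance an amine or a carboxylic acid in place of chloro. Also open, as far as these compounds go, is whether a simple acetyl group on the ring nitrogen would behave like the two arylsulfonyl groups that give numbers here.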